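The source may report more compounds than this note shows. Statements on the series, on what has been measured and on what is new or still open speak of the compounds shown alone.

Measured in an ADME assay on microsomes from liver (Homo sapiens) for metabolic stability, read by LC-MS, using NADPH, with a stated time of 30 min, tested at 0.1 uM, in the presence of a further agent that is not named here (on this read-out higher numbers stand for a more stable compound and lower numbers for a less stable compound), each value being a limit of the assay and not a number:

Compound 1 `Nc1ccc(-c2cnc(N)c(-c3ccc(N)nc3)n2)cn1`: > 90%
Compound 2 `Nc1ncc(-c2ccc(C(=O)N3CC(O)C3)cc2)nc1-c1ccc(C(F)(F)F)cc1`: > 90%
Compound 3 `Nc1ccc(-c2nc(-c3ccc(S(=O)(=O)C4CC4)cc3)cnc2N)cn1`: > 90%

Compound 3 therefore stands at > 90%, which is a limit. It shares this position with the other two compounds, as the limit of > 90% in this assay, at which 3 of the 3 values shown sit, shows. Compound 4 `CS(=O)(=O)c1ccc(-c2cnc(N)c(-c3ccc(N)nc3)n2)cc1` has methyl in place of cyclopropyl on a sulfonyl sulfur. Among the compounds with values here, no measured step shows what this change does. In this assay, the expected change stays within the usual scatter, with no direction favoured, an estimated step that the limit leaves unreadable from compound 3 to compound 4. Compound 4 is expected at 92%, with an estimated range from 80% to 100%.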

Compound 4, percent of the compound remaining in the Homo sapiens assay: > 90%
Compound 4 gave a limit, no number (the forecaster's own chance of this, stated with the estimate: 70%); the middle value lies beyond the limit too.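

In the Homo sapiens assay compound 3 gives > 90% as a limit of the assay. In the Homo sapiens assay compound 4 gives > 90% as a limit of the assay. In the Homo sapiens assay no step can be read from compound 3 to compound 4, whose values are both limits of the assay: the limit of > 90% in the Homo sapiens assay, at which 4 of the 4 values shown sit.

From the compounds shown here alone, what methyl in place of cyclopropyl on a sulfonyl sulfur does to the percent remaining in the Homo sapiens assay stays open.

In a physicochemical assay for solubility, read by HPLC, using the shake flask method, with a stated time of 2 h, at pH 2 (a lower number here means a less soluble compound, a higher number a more soluble compound), compound 3 gives 212000 nM and compound 4 gives 206000 nM (that is a 1.0-fold lower number from compound 3 to compound 4 (0.01 log units; within the scatter))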